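The source may report more compounds than this note shows. Statements on the series, on what has been measured and on what is new or still open speak of the compounds shown alone.

Measured compounds:
- compound 1, `O=C(/C=C/c1ccc2c(c1)B(O)OC2)c1ccccc1`: 19100 nM
- compound 2, `O=C(/C=C/c1ccc2c(c1)B(O)OC2)c1ccc(I)cc1`: > 100000 nM (a limit)
- compound 3, `O=C(/C=C/c1ccc2c(c1)B(O)OC2)c1ccc(O)cc1`: > 100000 nM (a limit)

For the measured compounds named here, in a toxicity assay on WI-38 cells (Homo sapiens) for cytotoxicity, read by MTT assay, with a stated time of 48 h (on this read-out higher numbers stand for weaker inhibition and lower numbers for stronger inhibition), compound 1 gives 19100 nM, and this is the only number among the three values shown. For compound 2 the value > 100000 nM is a limit of the assay, not a number. For compound 3 the value > 100000 nM is likewise a limit. Going by the values given here, compound 1 thus stands as the only compound with a readable number, and the two others sit at the limit of > 100000 nM in this assay, at which 2 of the 3 values shown sit.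

Compound 4, `Cc1cccc(C(=O)/C=C/c2ccc3c(c2)B(O)OC3)c1`, differs from compound 1 in one place: methyl in place of hydrogen on an aromatic carbon. The two measured steps that bear on this change both start from compound 1 and both place a group on the same ring: an at least 5.2-fold higher number from compound 1 to compound 2 (0.71 log units; beyond the scatter) and an at least 5.2-fold higher number from compound 1 to compound 3 (0.71 log units; beyond the scatter). Both moved the number upward, beyond the scatter, though their full size is not readable since both end at a limit. Among the compounds with values here, on this basis a step upward from compound 1 to compound 4 is expected in this assay, of modest size, since methyl is a smaller entering group than iodo or hydroxy and no step with methyl itself has been measured.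

Compound 4 is therefore estimated at 40000 nM, with a range from 15000 nM to 100000 nM. This estimate means an expected step of a 2.1-fold higher number from compound 1 to compound 4 (0.32 log units; beyond the scatter).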

Compound 4, half-maximal inhibitory concentration: 16700 nM
The estimate for compound 4 lay 2.4-fold (0.38 log units) above the measured number; measured number inside the range.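

In this assay, methyl on an aromatic carbon, meta to a large group, gives no shift beyond the scatter: a 1.1-fold lower number from compound 1 to compound 4 (0.06 log units; within the scatter). This shows that putting a group on this ring does not in itself raise the number, which the two earlier steps, both upward, could not show. Compound 4 also stands apart from the two compounds with a 4-iodophenyl or 4-hydroxyphenyl group, with an at least 5.9-fold lower number from compound 2 to compound 4 (0.77 log units; beyond the scatter) and an at least 5.9-fold lower number from compound 3 to compound 4 (0.77 log units; beyond the scatter), so the upward steps seen so far hold for iodo and hydroxy but not for this methyl, and both steps give only a lower bound, the values of compound 2 and compound 3 being limits: the limit of > 100000 nM in this assay, at which 2 of the 4 values shown sit.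

The compounds shown leave open whether an amine or a carboxylic acid at this place would stay level with compound 1 or move toward the limit. They also leave open whether the gap between methyl and the iodo and hydroxy groups lies in the group or in its place on the ring, and the step between compound 2 and compound 3 cannot be read.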